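The compounds below may be only part of what the source reports. "The series", "measured", "known", "first", "only" and "open" are said of these compounds alone.

Working notes on the series. In an ADME assay on HT-29 cells (Homo sapiens) for cytotoxicity, read by MTT assay, with a stated time of 72 h (a higher number here means a weaker inhibitor, a lower number a stronger inhibitor), compound 1, with the structure `COc1ccc(C2=C(c3cc(OC)c(OC)c(OC)c3)C(=O)CC2O[SiH2]C(C)(C)C)cc1OC`, gives > 100 ug/mL, and this is a limit of the assay rather than a measured number. Compound 1 therefore stands at the weak end of the numbers shown, as stated in the limit of > 100 ug/mL in this assay, at which 1 of the 2 values shown sits. Compound 2, with the structure `COc1ccc(C2=C(c3cc(OC)c(OC)c(OC)c3)C(=O)C(OC(C)=O)C2)cc1Cl`, gives < 1 ug/mL in this assay, again a limit and not a number, as stated in the limit of < 1 ug/mL in this assay, at which 1 of the 2 values shown sits. Among the measured compounds shown here, compound 1 and compound 2 differ in more than one place, so no single step between them is set out; their two values show only that one sits at each limit of this assay.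

Compound 3, with the structure `COc1ccc(C2=C(c3cc(OC)c(OC)c(OC)c3)C(=O)CC2O[SiH2]C(C)(C)C)cc1`, is not yet measured in this assay. It differs from compound 1 as follows: hydrogen in place of methoxy on an aromatic carbon. For the measured compounds named here, no step between measured compounds covers this change, so the direction is open. Any movement is expected to stay near the weak end, with a step from compound 1 of an at least 1.6-fold lower number from compound 1 to compound 3 (0.22 log units; that floor lies within the scatter). Compound 3 is expected to give about 60 ug/mL in this assay, within the range 8 ug/mL to 150 ug/mL.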

Compound 3, half-maximal inhibitory concentration: > 100 ug/mL
Compound 3: no number, only a limit (the forecaster's own chance of this, stated with the estimate: 50%); middle value at least 1.6-fold (0.22 log units) away from the limit.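

No step can be read from compound 1 to compound 3, hydrogen in place of methoxy on an aromatic carbon, as both compounds stand at one limit of this assay: the limit of > 100 ug/mL in this assay, at which 2 of the 3 values shown sit.

The compounds shown leave open how far compound 1 and compound 3 lie past that limit, and whether this change moves the number at all.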